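Moving the nitro group on the urea aryl ring

This account rests on a few compounds, and the source may have more. Where it says the series, first, only, none or still open, it means among the compounds named here.

Measured compounds:
compound 1, `O=C(Nc1cccc(C(F)(F)F)c1)N[C@H]1CC[C@H](O)CC1`, > 20000 nM
compound 2, `O=C(Nc1ccccc1[N+](=O)[O-])N[C@H]1CC[C@H](Oc2ccc(F)cc2)CC1`, 3500 nM
compound 3, `O=C(Nc1ccccc1OC(F)(F)F)N[C@H]1CC[C@H](Oc2ccc(F)cc2)CC1`, > 20000 nM

Within the data shown here, in a functional assay on CRL2813 cells (Homo sapiens) for cytotoxicity, read by sulforhodamine B assay, with a stated time of 5 days (on this read-out higher numbers stand for weaker inhibition and lower numbers for stronger inhibition), compound 2 gives 3500 nM, the only number in the set. For compound 1 the result of > 20000 nM is a limit of the assay, not a number. For compound 3 the result of > 20000 nM is likewise a limit. Among the measured compounds shown here, compound 2 therefore stands alone as the one compound with a measured number, the other two sitting at the limit of > 20000 nM in this assay, at which 2 of the 3 values shown sit.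

Compound 4, `O=C(Nc1cccc([N+](=O)[O-])c1)N[C@H]1CC[C@H](Oc2ccc(F)cc2)CC1`, has not been measured. It differs from compound 2 in one place: 3-nitrophenyl in place of 2-nitrophenyl on an amide-type nitrogen. For the measured compounds named here, the one measured step, an at least 5.7-fold higher number from compound 2 to compound 3 (0.75 log units; beyond the scatter), swapped the group itself while keeping its place on the ring, so it does not bear directly on a move of the nitro group to another carbon; it shows only that this part of the molecule can change the outcome by a lot. Going by the values given here, no measured pair shows what the move itself does, and compound 1 with its hydroxy group cannot be compared.

For compound 4 a step of a 1.7-fold higher number from compound 2 to compound 4 (0.23 log units; within the scatter) is expected, with a value estimated at 6000 nM, between 1800 nM and 20000 nM.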

Compound 4, half-maximal inhibitory concentration: 6700 nM
Compound 4: middle estimate off by 1.1-fold (0.05 log units), on the low side; the measured number falls inside the stated range.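

In this assay, among these compounds, moving the nitro group gives a 1.9-fold higher number from compound 2 to compound 4 (0.28 log units; within the scatter), so on an amide-type nitrogen 3-nitrophenyl and 2-nitrophenyl cannot be told apart, and the earlier compounds offered no pair that could show this. The contrast lies with the exchange of the group itself, which gave an at least 5.7-fold higher number from compound 2 to compound 3 (0.75 log units; beyond the scatter): among the steps shown, changing the group at one place reads beyond the scatter, whereas changing where the nitro group sits does not. Compound 4 also gives the set a second measured number, which shows that activity in the low micromolar range here is not confined to the 2-nitrophenyl compound, while the remaining results stay at a limit of the assay: the limit of > 20000 nM in this assay, at which 2 of the 4 values shown sit.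

From the compounds shown here alone, two nitro-bearing compounds and one trifluoromethoxy compound are too few to say which feature of the aryl ring matters, and it remains open whether an amine, a nitrile or a carboxylic acid in place of the nitro group would give a number like those of compound 2 and compound 4. Compound 1, with its hydroxy group and trifluoromethyl group, differs from the others in more than one place, so what the aryl ether contributes also stays unresolved.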